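The source may hold more compounds than are shown below. What is called first, only, known or untested is meant among the compounds shown, and "the series" means these compounds.

Compound 1 `N#CC1=C(N)Oc2c(N)cc3nc4ccccc4nc3c2C12C(=O)N(Cc1cnnn1-c1cccc(Br)c1)c1ccccc12` gives > 50000 nM in a functional assay on HepG2 cells (Homo sapiens) for antiproliferative activity, read by MTT assay, with a stated time of 48 h (on this read-out lower numbers stand for stronger inhibition and higher numbers for weaker inhibition), which is a limit of the assay. Compound 2 `COc1ccccc1-n1nncc1CN1C(=O)C2(C(C#N)=C(N)Oc3c(N)cc4nc5ccccc5nc4c32)c2ccccc21` gives > 50000 nM in this assay, again a limit. Compound 3 `CCOc1ccccc1-n1nncc1CN1C(=O)C2(C(C#N)=C(N)Oc3c(N)cc4nc5ccccc5nc4c32)c2ccccc21` gives 30500 nM in this assay.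

Going by the values given here, compound 3 thus holds the only number in this set; the other two values are limits, both sitting at the limit of > 50000 nM in this assay, at which 2 of the 3 values shown sit. The step of an at least 1.6-fold lower number from compound 1 to compound 3 (0.21 log units; that floor lies within the scatter) and the step of an at least 1.6-fold lower number from compound 2 to compound 3 (0.21 log units; that floor lies within the scatter) are each a floor only, and the step that the two limits leave unreadable from compound 1 to compound 2 cannot be read. Compound 4 `Cc1ccc(C)c(-n2nncc2CN2C(=O)C3(C(C#N)=C(N)Oc4c(N)cc5nc6ccccc6nc5c43)c3ccccc32)c1` differs from compound 3 in one place: 2,5-dimethylphenyl in place of 2-ethoxyphenyl on an aromatic nitrogen. Among the compounds with values here, none of the measured steps exchanges the phenyl group for one carrying two methyls, so no step bears on this change directly. Within the data shown here, with two of three values at the limit and the one number weak, compound 4 is expected to stay in the same weak region, and the step of a 1.5-fold higher number from compound 3 to compound 4 (0.17 log units; within the scatter) is estimated to lie within the scatter. Compound 4 is therefore expected to give about 45000 nM in this assay, between 20000 nM and 100000 nM, with a real chance that only a limit is reported.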

Compound 4, half-maximal inhibitory concentration: > 50000 nM
Compound 4: no number, only a limit; the forecaster's own chance of this, stated with the estimate: 50%; middle value at least 1.1-fold (0.04 log units) from the limit.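

In this assay, 2,5-dimethylphenyl in place of 2-ethoxyphenyl on the aromatic nitrogen gives an at least 1.6-fold higher number from compound 3 to compound 4 (0.21 log units; that floor lies within the scatter), which is a floor only. The value of compound 4 is a limit, so a phenyl group carrying two methyls and no oxygen does not yield a number at this position. The steps from compound 1 and from compound 2 to compound 4 cannot be read, and the series now gathers at one edge of the read-out: the limit of > 50000 nM in this assay, at which 3 of the 4 values shown sit.

As far as these compounds go, whether compound 3 truly stands apart from the other three stays open, its floors to them lying within the scatter. From the compounds shown here alone, it is also open whether an amine or a carboxylic acid on the phenyl ring, or a longer chain in place of the ethoxy group, would bring a number well clear of this limit.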